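This account rests on a few compounds, and the source may have more. Where it says the series, first, only, none or still open, it means among the compounds named here.

The measured compounds:
compound 1, `COc1cccc(N2CCN(C(=O)C(C)N3C(=O)CCC3=O)CC2)c1`, gives 0%
compound 2, `CCC(C(=O)N1CCN(c2cccc(F)c2)CC1)N1C(=O)CCC1=O`, gives 0%
compound 3, `CC(C(=O)N1CCN(c2cccc(F)c2)CC1)N1C(=O)CCC1=O`, gives 0%

Each of these readings comes from a functional assay on the whole organism (strain Swiss) with Mus musculus as the target, in the maximal electroshock model, with a stated time of 2 h, at a dose of 100 mg/kg by the intraperitoneal route; on this read-out lower numbers stand for a weaker effect and higher numbers for a stronger effect at the one dose given. Compound 2 stands level with compounds 1 and 3 at the digits shown; its nearest neighbour is compound 1 and its furthest is compound 3, and in both cases the gap lies within the scatter. The unmeasured compound 4, `CCC(C(=O)N1CCN(c2cccc(C)c2)CC1)N1C(=O)CCC1=O`, differs from compound 2 in one place: methyl in place of fluoro on an aromatic carbon. Going by the values given here, two measured steps bear on this change. The exchange on the aromatic carbon, no change at the digits printed from compound 1 to compound 3 (within the scatter), and the exchange on the saturated chain carbon, no change at the digits printed from compound 2 to compound 3 (within the scatter), both left this assay unmoved. Every measured compound sits at the bottom of the read-out, and nothing among them suggests that a methyl in place of fluoro would move it. The step of no change at the digits printed from compound 2 to compound 4 (within the scatter) is therefore expected to be none beyond the scatter. Compound 4 is estimated at 0%, with an expected range from 0% to 10%.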

Compound 4, a percentage reported as activity, at one dose (the size of the read-out at that dose, not a potency): 0%
Compound 4: the middle estimate sits on the measured number at the digits printed, within the range that was stated.
By their numbers in this assay, from the lowest: compounds 1, 2, 3 and 4 (each within the scatter of the next).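

With no change at the digits printed from compound 2 to compound 4 (within the scatter) in this assay, the exchange of 3-fluorophenyl for 3-methylphenyl adds a third group at this aromatic carbon: methoxy and fluoro had already been seen there, and methyl now joins them, with compound 4 at 0%. Since all four compounds sit at the bottom of this read-out, the step shows only that methyl in place of fluoro does not lift compound 4 off that floor at the one dose given, and it cannot rank the two groups against each other. No measurement at hand offers an explanation for this result.

Still open, on these data alone, is whether an amine or a carboxylic acid at this aromatic carbon would raise the read-out. As far as these compounds go, it is equally open whether a longer chain on the saturated carbon would do so.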